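A few compounds are considered here, and "the series" means these few. Any claim that something is new, unique, unknown or untested is made for them only; others in the source may bear on it.

Compound 1 `CCc1cccc(C[C@H](O)/C=C/[C@H]2CSC(=O)N2CCSCCCC(=O)O)c1` carries an ethyl group on its aryl ring and is tested in a functional assay on CHO cells for agonist activity at prostaglandin E2 receptor EP4 subtype (Rattus norvegicus), read by cAMP accumulation and immunoassay, with a stated time of 10 min (a higher number here means that more compound is needed for the effect, a lower number that less compound is needed), where compound 1 gives 1.9 nM. Among the measured compounds shown here, compound 2 `COCc1cccc(C[C@H](O)/C=C/[C@H]2COC(=O)N2CCSCCCC(=O)O)c1` differs from compound 1 both in the ring of the shared core and in the substituent on the aryl ring; in this assay compound 2 gives 24 nM, a higher number that lies beyond the scatter, so that compound 1 holds the lower of the two numbers known so far. Compound 3 `COCc1cccc(C[C@H](O)/C=C/[C@H]2CSC(=O)N2CCSCCCC(=O)O)c1` keeps the core of compound 1 and changes only the aryl substituent: methoxy in place of methyl on a saturated chain carbon bound to an aromatic carbon. For the measured compounds named here, no pair differing in this one place alone has been measured, so the size of the step rests on expectation only; compound 2, which also carries the methoxymethyl group, gives the higher number. Compound 3 is expected to need somewhat more compound than compound 1, a step of a 2.6-fold higher number from compound 1 to compound 3 (0.42 log units; beyond the scatter), and its estimated value is 5 nM, in a range from 1.5 nM to 20 nM.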

Compound 3, half-maximal effective concentration: 2.4 nM
Compound 3: the middle estimate sits 2.1-fold (0.32 log units) above what was measured; the range from low to high includes it.
By their numbers in this assay, from the lowest: compounds 1 and 3 (each within the scatter of the next); then compound 2.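

In this assay, methoxy in place of methyl on a saturated chain carbon bound to an aromatic carbon gives a 1.3-fold higher number from compound 1 to compound 3 (0.10 log units; within the scatter), so on this core the 3-ethylphenyl and 3-(methoxymethyl)phenyl groups cannot be told apart. Compound 3 also shares the methoxymethyl group with compound 2 and differs from it only in the ring of the shared core; compound 2 gives 24 nM and compound 3 gives 2.4 nM, so the methoxymethyl group alone does not come with the higher number of compound 2. Nothing measured here offers an explanation for this result.

As far as these compounds go, it remains open whether an amine, a hydroxyl or a longer chain at this carbon would stay as close to compound 1. Also open, from the compounds shown here alone, is what number the ring of compound 2 would give with the ethyl group of compound 1 on the aryl ring.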